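A few compounds are considered here, and "the series" means these few. Any claim that something is new, unique, unknown or untested is made for them only; others in the source may bear on it.

Compound 1 `CCCCNc1nc(N)nc(C)c1CCCc1ccccc1`: 749 nM
Compound 2 `CCCCNc1nc(N)nc(C)c1C`: 3280 nM
Compound 3 `CCCCNc1nc(N)nc(C)c1CCCCO`: 1310 nM

In an assay on HEK293 cells for agonist activity at Toll-like receptor 8 (Homo sapiens), read by spectrophotometry (a lower number here means that less compound is needed, a higher number that more compound is needed for the effect), compound 3 stands with the second highest of these three numbers; compound 1 sits close to it, while compound 2 lies further away. Compound 4 `CCCCNc1nc(N)nc(C)c1CC` differs from compound 3 by hydrogen in place of 2-hydroxyethyl on a saturated chain carbon, two bonds along the chain from an aromatic carbon. Among the compounds with values here, two measured steps bear on this. The step of a 1.7-fold higher number from compound 1 to compound 3 (0.24 log units; within the scatter) shows that exchanging what the chain carries changes the number little. The step of a 2.5-fold lower number from compound 2 to compound 3 (0.40 log units; beyond the scatter) shows that adding 3-hydroxypropyl in place of hydrogen gave a modest gain. Compound 4 keeps only an ethyl on that carbon, and is therefore expected to move back toward compound 2, an estimated step of a 1.9-fold higher number from compound 3 to compound 4 (0.28 log units; within the scatter). Compound 4 is expected to give about 2500 nM, within a range from 1200 nM to 5000 nM.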

Compound 4, half-maximal effective concentration: 1660 nM
Compound 4: middle estimate off by 1.5-fold (0.18 log units), on the high side, within the range that was stated.
By their numbers in this assay, from the lowest: compounds 1, 3, 4 and 2 (each within the scatter of the next, the first and the last beyond it).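

Swapping the 2-hydroxyethyl for hydrogen keeps the number within the scatter, a 1.3-fold higher number from compound 3 to compound 4 (0.10 log units; within the scatter), so the hydroxyl-bearing chain shows no clear advantage over the plain ethyl of compound 4. The ethyl also stays within the scatter against the methyl, a 2.0-fold lower number from compound 2 to compound 4 (0.30 log units; within the scatter). Removing the benzyl gives a modest difference beyond the scatter, a 2.2-fold higher number from compound 1 to compound 4 (0.35 log units; beyond the scatter).

Nothing here explains these differences. Going by these compounds, it remains open whether an amine, a carboxylic acid or a longer chain at this position would give a number clearly apart from these.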